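Swapping 3-chlorophenyl for 4-bromophenyl: an expected step

A few compounds are considered here, and "the series" means these few. Any claim that something is new, unique, unknown or untested is made for them only; others in the source may bear on it.

- Compound 1 `NC1=NC2(CCSCC2)N(OCCCOc2ccc(Cl)c(Cl)c2)C(N)=N1` (1 nM)
- Compound 2 `CC(C)(C)c1ccc(OCCCON2C(N)=NC(N)=NC23CCSCC3)cc1` (1 nM)
- Compound 3 `NC1=NC2(CCSCC2)N(OCCCOc2cccc(Cl)c2)C(N)=N1` (60 nM)

In a functional assay on A549 cells (Homo sapiens) for antiproliferative activity, read by MTT assay, with a stated time of 72 h (a lower number here means a stronger inhibitor, a higher number a weaker inhibitor), compound 3 gives 60 nM as the highest number of the three. Compound 4 `NC1=NC2(CCSCC2)N(OCCCOc2ccc(Br)cc2)C(N)=N1` has 4-bromophenyl in place of 3-chlorophenyl on an oxygen on a saturated carbon. For the measured compounds named here, no measured step makes this exact swap. The closest evidence is a 60-fold higher number from compound 1 to compound 3 (1.78 log units; beyond the scatter), with hydrogen in place of chloro on an aromatic carbon. It shows that one change on the ring can move the number a long way in this small set. Compound 2 also reaches 1 nM with a different group on that ring. As far as these compounds go, a large step towards a lower number is therefore expected, though with wide uncertainty, since bromo itself is untested here. The estimated change is a 10-fold lower number from compound 3 to compound 4 (1.00 log units; beyond the scatter) in this assay, and it remains only an expectation. Compound 4 is expected at 6 nM, with an estimated range from 1 nM to 40 nM in this measurement.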

Compound 4, half-maximal inhibitory concentration: 740 nM
Beside the measured number, compound 4's estimate is 120-fold (2.09 log units) below it, outside the stated range (above it).
By their numbers in this assay, from the lowest: compounds 1 and 2 (each within the scatter of the next); then compound 3; then compound 4.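

In this assay there is a 12-fold higher number from compound 3 to compound 4 (1.09 log units; beyond the scatter) when 3-chlorophenyl gives way to 4-bromophenyl, so a single halogen on this ring does not by itself bring the number down. The distance to the low-number compounds is larger still: there is a 740-fold higher number from compound 1 to compound 4 (2.87 log units; beyond the scatter) with 4-bromophenyl in place of 3,4-dichlorophenyl, and a 740-fold higher number from compound 2 to compound 4 (2.87 log units; beyond the scatter) with bromo in place of tert-butyl on an aromatic carbon, so this ring is highly sensitive to what it carries. Nothing measured here gives a cause for these steps.

As far as these compounds go, the swap from compound 3 to compound 4 changes both the halogen and its place on the ring, so the share of each in the step stays open. From the compounds shown here alone, a 4-chlorophenyl or a 3-bromophenyl group would separate the two, and how a ring bearing an amine or a methoxy group would behave also remains open.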